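A few compounds are considered here, and "the series" means these few. Any claim that something is new, unique, unknown or untested is made for them only; others in the source may bear on it.

Measured so far in a functional assay on HCT-116 cells (Homo sapiens), read by MTT assay, with a stated time of 72 h; on this read-out lower numbers stand for stronger inhibition and higher numbers for weaker inhibition:
compound 1, `O=c1[nH]cnc2c1c(-c1ccoc1)cn2[C@@H]1O[C@H](CO)[C@@H](O)[C@H]1O`, gives 10300 nM.
compound 2, `Cc1nc(N)c2c(-c3ccoc3)cn([C@@H]3O[C@H](CO)[C@@H](O)[C@H]3O)c2n1`, gives > 20000 nM, which is a limit of the assay and not a number.
compound 3, `O=c1[nH]cnc2c1c(-c1cc3ccccc3o1)cn2[C@@H]1O[C@H](CO)[C@@H](O)[C@H]1O`, gives > 20000 nM, which is likewise a limit of the assay and not a number.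

Compound 1 and compound 3 share one core and differ in a single place: 1-benzofuran-2-yl in place of furan-3-yl on an aromatic carbon. In this assay this change gave an at least 1.9-fold higher number from compound 1 to compound 3 (0.28 log units; that floor lies within the scatter). Compound 2 carries a different core; how the two cores differ is not broken down here. Compound 4, `Cc1nc(N)c2c(-c3cc4ccccc4o3)cn([C@@H]3O[C@H](CO)[C@@H](O)[C@H]3O)c2n1`, has not yet been measured; it stands to compound 2 as compound 3 stands to compound 1, through the same kind of change, (1-benzofuran-2-yl in place of furan-3-yl on an aromatic carbon), at a place described in the same words. The floor at which two of the three values sit, (the limit of > 20000 nM in this assay, at which 2 of the 3 values shown sit), means the measured step is known only as a minimum.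

Compound 4 is expected at 40000 nM, between 20000 nM and 150000 nM, and most likely the assay will again report only a limit for it. The step so expected is a step that the limit leaves unreadable from compound 2 to compound 4, set against the earlier one. This rests on compound 2 already giving only a limit, > 20000 nM. It rests also on the measured change having moved toward weaker inhibition, an at least 1.9-fold higher number from compound 1 to compound 3 (0.28 log units; that floor lies within the scatter).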

Compound 4, half-maximal inhibitory concentration: > 20000 nM
Compound 4 gave a limit, no number; the forecaster's own chance of this, stated with the estimate: 90%; the middle value does not contradict the limit.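

Among these compounds, compound 2 and compound 4 both stand only at a limit of the assay and not at a number, so no step between them can be read in this assay. The compounds shown leave open whether 1-benzofuran-2-yl in place of furan-3-yl changes the inhibition at all on the core of compound 2, with most values resting at one floor: the limit of > 20000 nM in this assay, at which 3 of the 4 values shown sit.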